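The source may report more compounds than this note shows. Statements on the series, on what has been measured and on what is new or still open speak of the compounds shown alone.

In a functional assay on Jurkat cells for inhibition of nuclear factor NF-kappa-B complex (Homo sapiens) (a higher number here means a weaker inhibitor, a lower number a stronger inhibitor), compound 2 `CCOC(=O)c1cnc(-c2cc(Cl)nc(Cl)c2)nc1NN1C(=O)C=C(C)C1=O` gives 2000 nM, the second highest of the three numbers. Compound 1 `CCOC(=O)c1cnc(C(C)(C)C)nc1NN1C(=O)C=C(C)C1=O` gives 1000 nM, a step of a 2.0-fold higher number from compound 1 to compound 2 (0.30 log units; within the scatter). Compound 3 `CCOC(=O)c1cnc(-c2cccc([N+](=O)[O-])c2)nc1NN1C(=O)C=C(C)C1=O` gives 7000 nM, a step of a 3.5-fold higher number from compound 2 to compound 3 (0.54 log units; beyond the scatter), and from compound 1 the step is a 7.0-fold higher number from compound 1 to compound 3 (0.85 log units; beyond the scatter). Compound 4 `CCOC(=O)c1cnc(Oc2ccccc2)nc1NN1C(=O)C=C(C)C1=O` differs from compound 2 by phenoxy in place of 2,6-dichloropyridin-4-yl on an aromatic carbon. Going by the values given here, no measured step replaces this group with an aryl ether, so the three steps give only a loose guide: swapping among groups on this aromatic carbon has moved this assay by modest amounts or stayed within the scatter. Compound 4 is therefore expected to give 3000 nM, with a range from 800 nM to 12000 nM, a step of a 1.5-fold higher number from compound 2 to compound 4 (0.18 log units; within the scatter) that is expected to lie near the scatter.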

Compound 4, half-maximal inhibitory concentration: 15000 nM
Compound 4: middle estimate off by 5.0-fold (0.70 log units), on the low side; the measured number lies above the stated range.
By their numbers in this assay, from the lowest: compounds 1 and 2 (each within the scatter of the next); then compound 3; then compound 4.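

In this assay phenoxy gives the highest number of the four on this carbon between two ring nitrogen atoms (a 7.5-fold higher number from compound 2 to compound 4 (0.88 log units; beyond the scatter)), and it also stands above the 3-nitrophenyl group (a 2.1-fold higher number from compound 3 to compound 4 (0.33 log units; beyond the scatter)). Going by these compounds alone, the change from tert-butyl (a 15-fold higher number from compound 1 to compound 4 (1.18 log units; beyond the scatter)) is the only large step here, so changes at this position can move the number further than the earlier groups showed. Nothing available accounts for this rise. The compounds shown leave open whether the ether oxygen or the ring it carries matters more, a question that an unsubstituted phenyl or a phenylamino group on this carbon could address.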